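This account rests on a few compounds, and the source may have more. Where it says the series, first, only, none or still open, it means among the compounds named here.

Of the compounds shown here, three have been measured in an assay on HEK293 cells for displacement of a labelled ligand from 5-hydroxytryptamine receptor 4 (Homo sapiens), read by scintillation counting; on this read-out higher numbers stand for weaker inhibition and lower numbers for stronger inhibition. Compound 1 `COc1cc(N)c(Cl)cc1C(=O)NC1CCNCC1` gives 1580 nM, compound 2 `COc1cc(N)c(Cl)cc1C(=O)NCCN1CCNCC1` gives 1260 nM, and compound 3 `CC(C)n1c(=O)n(C(=O)NCC2CCNCC2)c2ccccc21` gives 39.8 nM, the lowest of the three numbers and beyond the scatter from both of the others. Compound 4 `CC(C)n1c(=O)n(C(=O)NC2CCNCC2)c2ccccc21` has not yet been measured. It differs from compound 3 in one place: piperidin-4-yl in place of (piperidin-4-yl)methyl on an amide-type nitrogen. Going by the values given here, no measured pair shows this change on the shared core of compound 3, and compounds 1 and 2, which carry different linkers on a different core, lie within the scatter of each other. A modest weakening is expected, with the step from compound 3 to compound 4 estimated as a 2.5-fold higher number from compound 3 to compound 4 (0.40 log units; beyond the scatter). Compound 4 is therefore expected to give about 100 nM in this assay, within 25 nM to 400 nM.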

Compound 4, inhibition constant: 1580 nM
For compound 4 the middle estimate is 16-fold (1.20 log units) below the measured one; measured number above the stated range.
By their numbers in this assay, from the lowest: compound 3; then compounds 2, 1 and 4 (each within the scatter of the next).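

In this assay, going by these compounds alone, putting piperidin-4-yl in place of (piperidin-4-yl)methyl on the amide-type nitrogen gives a 40-fold higher number from compound 3 to compound 4 (1.60 log units; beyond the scatter), the first direct reading of this change on the shared core. The group changes only slightly, with the same ring and the same counts of donors and acceptors, yet the step is large, so this position is sensitive to the change. No available measurement explains the size of this step. From the compounds shown here alone, whether a longer chain, such as a (piperidin-4-yl)ethyl group, would give a lower or higher number than compound 3 remains open. So does whether the same change would produce a similar step on the core of compound 1.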